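The source may report more compounds than this note shows. Statements on the series, on what has been measured and on what is new or still open speak of the compounds shown alone.

Compound 1 `COc1cc([C@H]2C[C@]2(CO)C(=O)Nc2ccccc2Cl)cc(OC)c1OC` stands as the weaker of the two numbered values in a functional assay on SW480 cells (Homo sapiens) for cytotoxicity, read by MTT assay, with a stated time of 48 h (a lower number here means a stronger inhibitor, a higher number a weaker inhibitor), where compound 1 gives 40200 nM. Its mirror image, compound 3 `COc1cc([C@@H]2C[C@@]2(CO)C(=O)Nc2ccccc2Cl)cc(OC)c1OC`, gives 10700 nM in this assay; the change is a 3.8-fold lower number from compound 1 to compound 3 (0.57 log units; beyond the scatter), a step that rests on (the fact that compounds 1 and 3 differ only in the configuration as drawn). Compound 2 `CCOC(=O)[C@]1(C(=O)Nc2ccccc2Cl)C[C@@H]1c1cc(OC)c(OC)c(OC)c1` carries ethoxycarbonyl in place of hydroxymethyl on a saturated ring carbon and in this assay returns only a limit, > 100000 nM. The step of an at least 2.4-fold higher number from compound 1 to compound 2 (0.39 log units; beyond the scatter) is therefore read against (the limit of > 100000 nM in this assay, at which 1 of the 3 values shown sits).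

Compound 4 `COc1cc([C@H]2C[C@]2(CO)C(=O)Nc2ccccc2)cc(OC)c1OC` differs from compound 1 by hydrogen in place of chloro on an aromatic carbon, at an aromatic carbon ortho to a large group. Neither measured step touches that ring: one alters the group on the saturated ring carbon, the other inverts configuration. Among the measured compounds shown here, no step at this position has been measured, so the expectation rests on compound 1 alone, with a step in this assay expected to stay close to the scatter and lean, if anything, toward a higher number. The expected step is a 1.2-fold higher number from compound 1 to compound 4 (0.09 log units; within the scatter). For compound 4 the estimate in this assay is 50000 nM, within 15000 nM to 150000 nM.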

Compound 4, half-maximal inhibitory concentration: > 100000 nM
Compound 4: only a limit was reported; the forecaster's own chance of this, stated with the estimate: 25%; middle value at least 2.0-fold (0.30 log units) away from the limit.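

The earlier compounds shown here all keep the 2-chlorophenyl group, and changing it to phenyl gives an at least 2.4-fold higher number from compound 1 to compound 4 (0.39 log units; beyond the scatter), so the chloro is not a silent passenger in this assay. Going by these compounds, the value for compound 4 is a limit, so the true size of this step stays unknown and can only be read as a minimum: the limit of > 100000 nM in this assay, at which 2 of the 4 values shown sit. Compound 1 now falls to the limit with a change at either of two places, the hydroxymethyl on the saturated ring carbon (compound 2) or the chloro on the aromatic carbon (compound 4), whereas compound 3, its mirror image, keeps a measurable number.

On these data alone, whether chloro in particular matters, or any group larger than hydrogen would serve here, remains open; fluoro, bromo, methyl or methoxy at this carbon would separate those readings. Also open, as far as these compounds go, is how the phenyl change behaves in the configuration of compound 3.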